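This account rests on a few compounds, and the source may have more. Where it says the series, first, only, none or still open, it means among the compounds named here.

Measured compounds:
- compound 1, `CCOC(=O)CC(CC)CCCCCn1c(C)nc(-c2ccccc2)c1-c1ccccc1`: 9900 nM
- compound 2, `Cc1nc(-c2ccccc2)c(-c2ccccc2)n1CCCCCC(C)NC(=O)Oc1ccccc1F`: 4.2 nM

Two compounds share the core and differ in the chain and its end group. In an assay on H4 cells for inhibition of Fatty-acid amide hydrolase 1 (Homo sapiens) (a higher number here means a weaker inhibitor, a lower number a stronger inhibitor), compound 1 gives 9900 nM, while compound 2, which carries a carbamate end group on a chain with a methyl on the carbon bearing the amide-type nitrogen, gives 4.2 nM. Compound 2 thus stands at the lowest of the two numbers, with compound 1 far higher, a gap well beyond the scatter. Within the data shown here, no step between compounds differing in one place is available, so the gap between compound 1 and compound 2 can only be read as what the two values show.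

Compound 3, `CCC(CCCCCn1c(C)nc(-c2ccccc2)c1-c1ccccc1)NC(=O)Oc1ccccc1F`, keeps the carbamate end group and the chain of compound 2, with one change: methyl in place of hydrogen on a saturated chain carbon, two bonds along the chain from an amide-type nitrogen. This is a small addition on a chain carbon. Among the measured compounds shown here, the study gives no single-point comparison of this kind, so there is no measured precedent for its size or direction. Compound 3 is therefore expected to stay close to compound 2, with the step of a 1.4-fold higher number from compound 2 to compound 3 (0.15 log units; within the scatter) expected to fall within the scatter or slightly beyond it toward a higher number. The estimate for compound 3 in this assay is 6 nM, within 2 nM to 20 nM.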

Compound 3, half-maximal inhibitory concentration: 30 nM
Beside the measured number, compound 3's estimate is 5.0-fold (0.70 log units) below it; the whole stated range lies below it.
By their numbers in this assay, from the lowest: compound 2; then compound 3; then compound 1.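

In this assay, the methyl in place of hydrogen on a saturated chain carbon, two bonds along the chain from an amide-type nitrogen, turns out not to be a silent addition: it gives a 7.1-fold higher number from compound 2 to compound 3 (0.85 log units; beyond the scatter), so the methyl to ethyl difference at this place shifts the number beyond the scatter, although it adds a single carbon. The change of end group can now also be read as one change, since ((2-fluorophenoxy)carbonyl)amino in place of (ethoxycarbonyl)methyl on a saturated chain carbon bound to two saturated chain carbons gives a 330-fold lower number from compound 1 to compound 3 (2.52 log units; beyond the scatter), a far larger step than the one from the added methyl, and compound 3 keeps most of the gain that the end group brings even with the ethyl in place. Nothing measured here offers a reason for either step.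

The compounds shown leave open whether a propyl group on this chain carbon would push the number higher still, or whether the trend would stop at ethyl. They also do not show how the chain carbon with only hydrogen, and no methyl at all, would compare with compound 2.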